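Thiosemicarbazone series on renal carcinoma cells: working notes

A few compounds are considered here, and "the series" means these few. Any claim that something is new, unique, unknown or untested is made for them only; others in the source may bear on it.

compound 1, `CC1=CC[C@H](C(C)(C)N=C=S)CC1`: > 100000 nM
compound 2, `CC1=CC[C@H](C(C)(C)NC(=S)NN)CC1`: > 100000 nM
compound 3, `COc1ccc(/C=N/NC(=S)NC(C)(C)[C@H]2CC=C(C)CC2)cc1`: 8900 nM

In a functional assay on 786-0 cells (Homo sapiens) for inhibition, read by sulforhodamine B assay, with a stated time of 48 h (on this read-out lower numbers stand for stronger inhibition of growth and higher numbers for weaker inhibition of growth), compound 1 gives only a limit, > 100000 nM. Compound 2 likewise gives only a limit, > 100000 nM. The step that the two limits leave unreadable from compound 1 to compound 2 is accordingly not readable. Going by the values given here, compound 3 gives 8900 nM in this assay, the only number in the set. Compound 1 and compound 2 sit at the limit of > 100000 nM in this assay, at which 2 of the 3 values shown sit.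

Compound 4, `CC1=CC[C@H](C(C)(C)NC(=S)N/N=C/c2ccccc2O)CC1`, carries 2-hydroxyphenyl in place of 4-methoxyphenyl on a carbon with a double bond to nitrogen. Among the compounds with values here, no measured step touches this end of the molecule; the one readable value belongs to compound 3, and the limits of compound 1 and compound 2 say nothing about it. The change is expected to move the value little, within the scatter, a 1.0-fold higher number from compound 3 to compound 4 (0.00 log units; within the scatter). Compound 4 is estimated at 9000 nM, with a range from 2500 nM to 35000 nM.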

Compound 4, concentration for 50% growth inhibition: 4600 nM
The estimate for compound 4 lay 2.0-fold (0.29 log units) above the measured number; measured number inside the range.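

Exchanging 4-methoxyphenyl for 2-hydroxyphenyl on a carbon with a double bond to nitrogen gives a 1.9-fold lower number from compound 3 to compound 4 (0.29 log units; within the scatter) in this assay. Going by these compounds alone, this is the first readable step, and it shows that this place accepts the exchange of these two groups without a change beyond the scatter. Nothing at hand gives a cause for this step.

Still open, on these data alone, is what a plain phenyl, or an aromatic ring carrying an amine or a carboxylic acid, would give at this place.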